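Stilbene sulfonamides: dimethylamino in place of fluoro

This account rests on a few compounds, and the source may have more. Where it says the series, first, only, none or still open, it means among the compounds named here.

The shared core is a stilbene bearing a primary sulfonamide, varied only on the other ring. Compound 1 `COc1cc(/C=C/c2ccc(S(N)(=O)=O)cc2)cc(OC)c1` carries two methoxy groups and in a functional assay on IGROV-1 cells (Homo sapiens) for inhibition (on this read-out lower numbers stand for stronger inhibition of growth and higher numbers for weaker inhibition of growth), compound 1 gives 23100 nM. Among the measured compounds shown here, compound 2 `COc1cccc(/C=C/c2ccc(S(N)(=O)=O)cc2)c1` keeps one methoxy and in this assay compound 2 gives 2500 nM; the single measured step, a 9.2-fold lower number from compound 1 to compound 2 (0.97 log units; beyond the scatter), shows that the substitution of this ring moves the number appreciably. Compound 3 `NS(=O)(=O)c1ccc(/C=C/c2ccc(F)cc2)cc1` carries a fluoro group and in this assay compound 3 gives 20900 nM, the second highest of the three numbers; compound 1 lies within the scatter of it, while compound 2 sits well below it, beyond the scatter.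

Compound 4 `CN(C)c1ccc(/C=C/c2ccc(S(N)(=O)=O)cc2)cc1` differs from compound 3 by dimethylamino in place of fluoro on an aromatic carbon, the new group standing on an aromatic carbon para to a large group. For the measured compounds named here, no measured step covers a dimethylamino group, so the only guide is that a change of the substituent on this ring can shift the number by about the size of the step from compound 1 to compound 2, in either direction. A modest lowering is expected, roughly a 3.5-fold lower number from compound 3 to compound 4 (0.54 log units; beyond the scatter), with wide uncertainty. Compound 4 is therefore estimated at 6000 nM, expected between 1200 nM and 30000 nM.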

Compound 4, concentration for 50% growth inhibition: 13400 nM
Estimate against measurement, compound 4: 2.2-fold (0.35 log units) below, within the range that was stated.
By their numbers in this assay, from the lowest: compound 2; then compounds 4, 3 and 1 (each within the scatter of the next).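

Replacing fluoro with dimethylamino on an aromatic carbon para to a large group, in this assay, gives a 1.6-fold lower number from compound 3 to compound 4 (0.19 log units; within the scatter) and so does not separate the two groups at this position. Dimethylamino brings more heavy atoms and a hydrogen-bond acceptor that fluoro lacks, yet this exchange leaves the read-out within the scatter, whereas the step between the two methoxy compounds (a 9.2-fold lower number from compound 1 to compound 2 (0.97 log units; beyond the scatter)) lies beyond it, so a change on this ring does not by itself guarantee a readable shift. Nothing available explains why compound 3 and compound 4 read alike in this assay.

Going by these compounds, whether a carboxylic acid, a primary amine or a longer alkyl chain at this same place would move the number beyond the scatter remains open. Also open, on these data alone, is whether the value of compound 2 (2500 nM) belongs to the methoxy group itself or to where that group stands on the ring.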